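Nitro Substitution on Compound 3: An Expected Small Step

The source may report more compounds than this note shows. Statements on the series, on what has been measured and on what is new or still open speak of the compounds shown alone.

Three measured compounds share one core. Compound 1 `CC(C)(C)c1cc(C(C)(C)C)c2oc(C(c3ccccc3)c3c[nH]c4ccccc34)cc2c1` gives 61600 nM in a functional assay on SiHa cells (Homo sapiens) for cytotoxicity; a higher number here means a weaker inhibitor, a lower number a stronger inhibitor. Compound 2 `CC(C)(C)c1cc(C(C)(C)C)c2oc(C(c3ccccc3)c3c[nH]c4ccc([N+](=O)[O-])cc34)cc2c1`, which carries a nitro group in place of a hydrogen, gives 48200 nM, and compound 3 `CC(C)(C)c1cc(C(C)(C)C)c2oc(C(c3ccc(Cl)cc3)c3c[nH]c4ccccc34)cc2c1`, with a chloro group in place of a hydrogen, gives 49800 nM. Compound 3 stands second highest of the three numbers and lies within the scatter of both compound 1 and compound 2. Compound 4 `CC(C)(C)c1cc(C(C)(C)C)c2oc(C(c3ccc(Cl)cc3)c3c[nH]c4ccc([N+](=O)[O-])cc34)cc2c1` differs from compound 3 by nitro in place of hydrogen on an aromatic carbon. The same change is already represented by one measured step: a 1.3-fold lower number from compound 1 to compound 2 (0.11 log units; within the scatter). The chloro step a 1.2-fold lower number from compound 1 to compound 3 (0.09 log units; within the scatter) likewise stayed within the scatter. No step beyond the scatter is therefore expected for compound 4 in this assay, and its value is estimated at 42000 nM, between 21000 nM and 84000 nM, which means an expected step of a 1.2-fold lower number from compound 3 to compound 4 (0.07 log units; within the scatter).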

Compound 4, half-maximal inhibitory concentration: 36900 nM
Compound 4: middle estimate off by 1.1-fold (0.06 log units), on the high side, within the range that was stated.
By their numbers in this assay, from the lowest: compounds 4, 2, 3 and 1 (each within the scatter of the next).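

With the chloro group present, nitro in place of hydrogen gives a 1.3-fold lower number from compound 3 to compound 4 (0.13 log units; within the scatter) and so reads alike on two cores: the same change on two cores in this assay, a 1.3-fold lower number (0.11 log units; within the scatter) from compound 1 to compound 2 and a 1.3-fold lower number (0.13 log units; within the scatter) from compound 3 to compound 4, 1.1-fold (0.02 log units) apart, within the scatter of two such steps. Read the other way, chloro in place of hydrogen gives a 1.3-fold lower number from compound 2 to compound 4 (0.12 log units; within the scatter) with the nitro group present, and this step also reads alike on both cores: the same change on two cores in this assay, a 1.2-fold lower number (0.09 log units; within the scatter) from compound 1 to compound 3 and a 1.3-fold lower number (0.12 log units; within the scatter) from compound 2 to compound 4, 1.1-fold (0.02 log units) apart, within the scatter of two such steps. Each single step in this assay thus stays within the scatter whether or not the other group is present. Going by these compounds, whether an amine or a carboxylic acid in place of that hydrogen would give a step beyond the scatter remains open.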